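Methyl on the Cyclobutane Ring: a Second Test

The source may report more compounds than this note shows. Statements on the series, on what has been measured and on what is new or still open speak of the compounds shown alone.

Measured compounds:
- compound 1, `C[C@]1(O)C[C@](c2cccc(OC(F)(F)F)c2)([C@H](O)c2ccccn2)C1`: 1310 nM
- compound 2, `O[C@H](c1ccccn1)[C@]1(c2cccc(OC(F)(F)F)c2)C[C@H](O)C1`: 40 nM
- compound 3, `O[C@H](c1ccccn1)[C@]1(c2ccc(C(F)(F)F)cc2)C[C@@H](O)C1`: 1870 nM

All three were tested in an assay on HEK293 cells for antagonist activity at transient receptor potential cation channel subfamily V member 3 (Homo sapiens), read by FLIPR and calcium flux; on this read-out lower numbers stand for stronger inhibition and higher numbers for weaker inhibition. Compound 2 gives the lowest number of the three. Compound 1 differs from compound 2 by one change, (methyl in place of hydrogen on a saturated ring carbon), and this change made a large step: a 33-fold higher number from compound 2 to compound 1 (1.52 log units; beyond the scatter). Compound 3 stands highest of the three numbers; its gap to compound 1 lies within the scatter, so no order between those two can be claimed, while its gap to compound 2 lies beyond it. How the core of compound 3 differs from the core of compound 2 is not broken down here.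

Compound 4, `C[C@]1(O)C[C@@](c2ccc(C(F)(F)F)cc2)([C@H](O)c2ccccn2)C1`, has not yet been measured. It differs from compound 3 by methyl in place of hydrogen on a saturated ring carbon, and the place of that change is described in the same words as for the pair of compound 2 and compound 1, so it is the same change on a different core. If the step carried over in full, compound 4 would be expected to land far higher than compound 3, because a 33-fold higher number from compound 2 to compound 1 (1.52 log units; beyond the scatter) was large. The core differs, however, and compound 3 already gives a high number, so the expected step from compound 3 to compound 4 in this assay is set somewhat smaller than the earlier one: an 11-fold higher number from compound 3 to compound 4 (1.03 log units; beyond the scatter). Compound 4 is thus estimated at 20000 nM, with a range from 4000 nM to 100000 nM, and a real chance that only a limit is reported.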

Compound 4, antagonist equilibrium constant: 840 nM
Compound 4: the middle estimate sits 24-fold (1.38 log units) above what was measured, outside the stated range (below it).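

In this assay, placing the methyl on the cyclobutane ring of compound 3 gave a 2.2-fold lower number from compound 3 to compound 4 (0.35 log units; beyond the scatter), a modest step, and its direction is opposite to the large rise seen when the same change was made on the core of compound 2. The two steps differ in both size and direction, so in this series the effect of this change cannot simply be carried from one core to another: the same change on two cores in this assay, a 33-fold higher number (1.52 log units; beyond the scatter) from compound 2 to compound 1 and a 2.2-fold lower number (0.35 log units; beyond the scatter) from compound 3 to compound 4, 73-fold (1.86 log units) apart, beyond the scatter of two such steps This shows that the core matters to the outcome, but it does not show which feature of the core matters, since the cores of compound 2 and compound 3 are not separated here into single differences, and two pairs are too few to give a rule for any further core.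

The compounds shown leave open whether a core differing from the core of compound 2 in only one place would follow the large rise or the modest fall. They also leave open how the same ring carbon would respond to a group other than methyl, such as an ethyl group or an amine, on either core.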